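Aryl swap at the saturated ring carbon of the fused core

The compounds below may be only part of what the source reports. "The series", "measured", "known", "first", "only" and "open" are said of these compounds alone.

Measured compounds:
compound 1 `N#CC1=C(N)N(c2ccc(S(N)(=O)=O)cc2)C2=C(CCCC2)C1c1ccccc1`: 30% in a functional assay on Ehrlich cells (Mus musculus) for cytotoxicity, read by trypan blue exclusion, with a stated time of 2 h, tested at 100 ug/mL; on this read-out higher numbers stand for a stronger effect at the one concentration tested and lower numbers for a weaker effect
compound 2 `Cc1ccc(C2C(C#N)=C(N)N(c3ccc(S(N)(=O)=O)cc3)C3=C2CCCC3)o1`: 30% in this assay

Compound 2 stands level with compound 1 on the numbers shown. Among the measured compounds shown here, the single step so far, no change at the digits printed from compound 1 to compound 2 (within the scatter), exchanged one aromatic group for another at the same saturated ring carbon and stayed within the scatter, so the series gives no sign yet that the group at this position moves the read-out.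

Compound 3 `N#CC1=C(N)N(c2ccc(S(N)(=O)=O)cc2)C2=C(CCCC2)C1c1cccs1` has not been measured. Its change from compound 2 is thiophen-2-yl in place of 5-methylfuran-2-yl on a saturated ring carbon. For the measured compounds named here, this is again an exchange of one aromatic group for another at the same place, and the only step that bears on it is the one from compound 1 to compound 2, which produced no change beyond the scatter. On that basis no step beyond the scatter is expected in this assay for compound 3 either, in neither direction.

The expected step is no change at the digits printed from compound 2 to compound 3 (within the scatter), and compound 3 is estimated at 30% with a range from 18% to 42%.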

Compound 3, a percentage reported as activity, at one concentration (the size of the read-out at that concentration, not a potency): 20%
For compound 3 the middle estimate is 10 percentage points above the measured one; low and high end bracket the measured number.
By their numbers in this assay, from the lowest: compounds 3, 1 and 2 (each within the scatter of the next).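

With thiophen-2-yl, the saturated ring carbon now carries a third aromatic group, and a ring with sulfur as its hetero atom in place of the oxygen of the furan: in this assay the exchange for 5-methylfuran-2-yl gives a number 10 percentage points lower from compound 2 to compound 3 (within the scatter), and the exchange for phenyl gives a number 10 percentage points lower from compound 1 to compound 3 (within the scatter). Neither step leaves the scatter, so phenyl, 5-methylfuran-2-yl and thiophen-2-yl cannot be told apart at this position in this assay, and this holds for the six-membered and the five-membered aromatic rings alike. No measurement is at hand that would bear on these small differences, and none is read into them.

Open, going by these compounds, is whether anything other than an aromatic ring on this carbon would move the read-out, for instance a carboxylic acid, an aminomethyl group or a longer alkyl chain. Also open, on these data alone, is how these compounds compare at other concentrations, since a single concentration gives the size of the effect there and not a potency.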